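This account rests on a few compounds, and the source may have more. Where it says the series, first, only, none or still open, it means among the compounds named here.

Compound 2, `CC1CCN(C(=O)c2sc(-c3ccc(S(C)(=O)=O)c([N+](=O)[O-])c3)nc2C(F)(F)F)CC1`, gives 6400 nM in a physicochemical assay for solubility, in phosphate buffer, at pH 7.4; on this read-out lower numbers stand for lower solubility and higher numbers for higher solubility. Among the three measured compounds it holds the second highest of the numbers: its nearest neighbour is compound 1, `Cc1nc(-c2ccc(S(C)(=O)=O)c([N+](=O)[O-])c2)sc1C(=O)N1CCC(C)CC1`, which gives 6700 nM, and its furthest is compound 3, `Cc1nc(-c2ccc(S(C)(=O)=O)c([N+](=O)[O-])c2)sc1C(=O)N1CC2(C)CC1CC(C)(C)C2`, which gives 5700 nM; both gaps are within the scatter. Among the measured compounds shown here, the one measured step, a 1.0-fold lower number from compound 1 to compound 2 (0.02 log units; within the scatter), changes the group on the aromatic carbon and does not touch the amide. Compound 4, `CN(Cc1cccc(F)c1)C(=O)c1sc(-c2ccc(S(C)(=O)=O)c([N+](=O)[O-])c2)nc1C(F)(F)F`, differs from compound 2 at the carbonyl carbon: (3-fluorobenzyl)(methyl)amino in place of 4-methylpiperidin-1-yl on a carbonyl carbon. For the measured compounds named here, no measured step covers a change at this place; compounds 1 and 3 differ there as well, yet their values show only a gap within the scatter. With nothing in the measured steps pointing either way, the expectation for compound 4 is a step of about a 1.4-fold lower number from compound 2 to compound 4 (0.15 log units; within the scatter), that is, no change beyond the scatter. Compound 4 is therefore estimated at 4500 nM in this assay, with a range from 1500 nM to 13000 nM.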

Compound 4, solubility: 1200 nM
Compound 4: middle estimate off by 3.8-fold (0.57 log units), on the high side; the measured number lies below the stated range.
By their numbers in this assay, from the lowest: compound 4; then compounds 3, 2 and 1 (each within the scatter of the next).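

In this assay, (3-fluorobenzyl)(methyl)amino in place of 4-methylpiperidin-1-yl on a carbonyl carbon gives a 5.3-fold lower number from compound 2 to compound 4 (0.73 log units; beyond the scatter), the only step shown that lies beyond the scatter. This shows that the group on the carbonyl carbon can shift this read-out, something compounds 1, 2 and 3 did not reveal, as their values all lie within the scatter of one another. Nothing measured here accounts for the size of this step.

The compounds shown do not separate the contributions of the fluorine, the benzyl group and the replacement of the piperidine ring, so a plain benzyl(methyl)amino group or a morpholin-4-yl group on the same carbonyl carbon would be informative. From the compounds shown here alone, it also remains open whether the step would be of similar size with methyl rather than trifluoromethyl on the aromatic carbon.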